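Swapping Bromo for Chloro on a Chalcone Boronic Acid

The source may report more compounds than this note shows. Statements on the series, on what has been measured and on what is new or still open speak of the compounds shown alone.

Three compounds have been measured:
compound 1 `O=C(/C=C/c1ccc(I)cc1)c1ccc(OCB(O)O)cc1`, 9500 nM;
compound 2 `O=C(/C=C/c1ccc(F)c(Br)c1)c1ccc(B(O)O)cc1`, 8500 nM;
compound 3 `O=C(/C=C/c1ccccc1)c1ccc[nH]1`, 9000 nM.

In a functional assay on MCF7 cells (Homo sapiens) for inhibition (a lower number here means a stronger inhibitor, a higher number a weaker inhibitor), compound 2 gives the lowest of the three numbers, yet its gaps to compound 3 and to compound 1 both lie within the scatter, so the three stand level. Compound 4 `O=C(/C=C/c1ccc(F)c(Cl)c1)c1ccc(B(O)O)cc1` has not yet been measured. It differs from compound 2 in one place: chloro in place of bromo on an aromatic carbon. Among the compounds with values here, the bromo leaves and a chloro enters, both single heavy atoms without donors, acceptors or charge; no measured pair shows such a swap here. Compound 4 is therefore expected to stay close to compound 2, with a step of a 1.1-fold higher number from compound 2 to compound 4 (0.02 log units; within the scatter) that is not beyond the scatter. The estimate for compound 4 is 9000 nM, in the range 4000 nM to 20000 nM.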

Compound 4, half-maximal inhibitory concentration: 6000 nM
For compound 4 the middle estimate is 1.5-fold (0.18 log units) above the measured one; the measured number falls inside the stated range.
By their numbers in this assay, from the lowest: compounds 4, 2, 3 and 1 (each within the scatter of the next).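

Within the data shown here, on the aromatic carbon ortho to a fluoro group, chloro in place of bromo gives the first measured step at this position: a 1.4-fold lower number from compound 2 to compound 4 (0.15 log units; within the scatter) in this assay on the shared core. Compound 2 and compound 4 therefore stand level, and this read-out does not separate bromo from chloro at this place.

The compounds shown leave open whether a methoxy group or an amine on this same carbon would stay level with compound 2 and compound 4. Nothing available explains the size of this step.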